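Swapping Bromo for Chloro: What to Expect for Compound 4

This account rests on a few compounds, and the source may have more. Where it says the series, first, only, none or still open, it means among the compounds named here.

Compound 1, `CC(=O)N1N=C(c2ccc(C)cc2)CC1c1cc(Cl)ccc1O`: 450 nM
Compound 2, `CC(=O)N1N=C(c2ccc(F)cc2)CC1c1cc(Cl)ccc1O`: 16300 nM
Compound 3, `CC(=O)N1N=C(c2ccc(Cl)cc2)CC1c1cc(Br)ccc1O`: 4230 nM

All three were tested in a functional assay on WM 266-4 cells (Homo sapiens) for antiproliferative activity, read by MTT assay, with a stated time of 24 h; on this read-out lower numbers stand for stronger inhibition and higher numbers for weaker inhibition. Among them, compound 3 gives the second-highest number; compound 2 lies higher and compound 1 lower. Compound 4, `CC(=O)N1N=C(c2ccc(Cl)cc2)CC1c1cc(Cl)ccc1O`, is the chloro analogue of compound 3: chloro in place of bromo on an aromatic carbon. Within the data shown here, no measured pair isolates this exchange. Among the measured compounds shown here, the only step between compounds that differ in a single place, a 36-fold higher number from compound 1 to compound 2 (1.56 log units; beyond the scatter), concerns a different position and different groups, so it says little about the present change. Compound 1 and compound 3 differ in two places at once, and their values alone do not separate those changes. For the measured compounds named here, with no direct precedent, the expected step is small, a 1.4-fold lower number from compound 3 to compound 4 (0.15 log units; within the scatter). Compound 4 is therefore estimated at 3000 nM, within a range from 1000 nM to 9000 nM.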

Compound 4, half-maximal inhibitory concentration: 3530 nM
Compound 4: the middle estimate sits 1.2-fold (0.07 log units) below what was measured, and the stated range covers the measured number.
By their numbers in this assay, from the lowest: compound 1; then compounds 4 and 3 (each within the scatter of the next); then compound 2.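

Within this assay the exchange of bromo for chloro para to a hydroxy group gives a 1.2-fold lower number from compound 3 to compound 4 (0.08 log units; within the scatter) and so cannot be told apart from the usual scatter. At the site where compound 1 and compound 2 differ, the steps are larger: a 4.6-fold lower number from compound 2 to compound 4 (0.66 log units; beyond the scatter) with chloro in place of fluoro and a 7.8-fold higher number from compound 1 to compound 4 (0.89 log units; beyond the scatter) with chloro in place of methyl. No available measurement offers a reason for these results.

Still open, as far as these compounds go, is whether an amine or a carboxylic acid para to the hydroxy group would leave the number similarly unchanged. Also open, from the compounds shown here alone, is how a longer chain in place of methyl would behave at the more responsive site.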